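The compounds below may be only part of what the source reports. "The series", "measured", "known", "first", "only" and "open" are said of these compounds alone.

Measured so far:
Compound 1 `COc1cc(-c2cc(/C=C/C(=O)c3ccc(N)cc3)[nH]n2)cc(OC)c1OC` gives 96% in a functional assay on SNB-19 cells (Homo sapiens) for cytotoxicity, read by sulforhodamine B assay, with a stated time of 48 h, tested at 0.01 uM; a lower number here means a stronger effect, a higher number a weaker effect of the compound at the concentration tested.
Compound 2 `COc1ccc(C(=O)/C=C/c2cc(-c3cc(OC)c(OC)c(OC)c3)n[nH]2)cc1OC` gives 91% in this assay.

The two measured compounds share one core and differ only in the ring that sits on the carbonyl carbon. Going by the values given here, the single step between them, a number 5 percentage points lower from compound 1 to compound 2 (within the scatter), swapped 4-aminophenyl for 3,4-dimethoxyphenyl, and the numbers barely moved. Compound 2 therefore stands lowest of the two numbers, but its nearest neighbour, compound 1, is within the scatter, so the two cannot be ranked.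

Compound 3 `COc1ccc(C(=O)/C=C/c2cc(-c3cc(OC)c(OC)c(OC)c3)n[nH]2)cc1` is the next compound, not yet measured. The change from compound 2 is hydrogen in place of methoxy on an aromatic carbon, which again touches only the ring on the carbonyl carbon, cutting it from 3,4-dimethoxyphenyl to 4-methoxyphenyl. Among the compounds with values here, the only step that bears on this, the one from compound 1 to compound 2, changed that same ring and stayed within the scatter. On that basis a step of about a number 1 percentage points higher from compound 2 to compound 3 (within the scatter) is expected, that is none beyond the scatter, in either direction. Compound 3 is estimated at 92% in this assay, within a range from 80% to 102%.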

Compound 3, a percentage reported as activity, at one concentration (the size of the read-out at that concentration, not a potency): 97%
The estimate for compound 3 lay 5 percentage points below the measured number, within the range that was stated.
By their numbers in this assay, from the lowest: compounds 2, 1 and 3 (each within the scatter of the next).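

Hydrogen in place of methoxy on the ring on the carbonyl carbon, which cuts 3,4-dimethoxyphenyl to 4-methoxyphenyl, leaves the read-out in this assay unchanged beyond the scatter (a number 6 percentage points higher from compound 2 to compound 3 (within the scatter)), so at this concentration the methoxy group that leaves, ortho to a methoxy group, makes no difference that can be read. The group on this ring can now also be compared directly, with methoxy in place of amino on an aromatic carbon (a number 1 percentage points higher from compound 1 to compound 3 (within the scatter)), and these two groups cannot be told apart here either, leaving all three compounds unranked. No measurement at hand offers an explanation for these results.

Still open, going by these compounds, is whether any change on this ring can move the number beyond the scatter, for example a carboxylic acid or a longer chain such as butoxy in place of the methoxy group of compound 3. Also open, on these data alone, is whether these compounds would separate at a higher concentration, where the read-out might show differences that this single low concentration cannot.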